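Permeability notes on the oxazole-piperidine amide series

A few compounds are considered here, and "the series" means these few. Any claim that something is new, unique, unknown or untested is made for them only; others in the source may bear on it.

Measured so far:
compound 1 `Cc1ccccc1-c1nc(CN2CCC(C(=O)NCCCN3CC(C)(C)CC(C)(C)C3)CC2)c(C)o1`, > 1390 10^-6 cm/s
compound 2 `Cc1oc(-c2c(Cl)cccc2C(F)(F)F)nc1CN1CCC(C(=O)NCCCN2C[C@H](C)C[C@H](C)C2)CC1`, "not determined" (no result reported)

In a physicochemical assay for permeability, using PAMPA (on this read-out higher numbers stand for higher permeability and lower numbers for lower permeability), compound 1 reaches > 1390 10^-6 cm/s, which is a limit of the assay and not a number. For the measured compounds named here, this is the sole reading in the set, and it is the limit described as the limit of > 1390 10^-6 cm/s in this assay, at which 1 of the 2 values shown sits. Going by the values given here, compound 2 has no numerical standing in this assay: its entry is "not determined" (no result reported), so no measured step exists between compound 2 and any other compound.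

Compound 3 `Cc1cc(C)cc(-c2nc(CN3CCC(C(=O)NCCCN4C[C@H](C)C[C@H](C)C4)CC3)c(C)o2)c1` is the next compound to be measured in this assay. It differs from compound 2 in one place: 3,5-dimethylphenyl in place of 2-chloro-6-(trifluoromethyl)phenyl on an aromatic carbon. Among the compounds with values here, with no result for compound 2, no measured step can anchor the direction or size of the change from compound 2 to compound 3 in this assay; no step beyond the usual scatter is claimed.

Within the data shown here, compound 3 is expected to read high in this assay, because compound 1, the only compound with a reading, gives > 1390 10^-6 cm/s. For compound 3 the estimate is 1200 10^-6 cm/s, within a range from 500 10^-6 cm/s to 2000 10^-6 cm/s.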

Compound 3, apparent permeability: 864 10^-6 cm/s
Beside the measured number, compound 3's estimate is 1.4-fold (0.14 log units) above it; the range from low to high includes it.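

No new step can be read from compound 3: the entry for compound 2 gives no number in this assay, and compound 1 differs from compound 3 in more than one place. The compounds shown leave open what the change from 2-chloro-6-(trifluoromethyl)phenyl to 3,5-dimethylphenyl on the shared core does to the reading in this assay.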